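Amide nitrogen substituent in the benzofuran carboxamide series

The source may report more compounds than this note shows. Statements on the series, on what has been measured and on what is new or still open speak of the compounds shown alone.

Measured compounds in a functional assay on the whole organism for inhibition, with Mus musculus as the target, at a dose of 10 mg/kg by the oral route; on this read-out lower numbers stand for less inhibition and higher numbers for more inhibition at the one dose given (going by the name of the read-out):
compound 1 `CNC(=O)c1cc2c(-c3ccccc3)ccc(OC)c2o1` 18%
compound 2 `COc1ccc(-c2ccccc2)c2cc(C(=O)Nc3ccc(Cn4ccnc4)cc3)oc12` 12%
compound 3 `COC(=O)c1ccc(OC)c2oc(C(=O)Nc3ccc(Cn4ccnc4)cc3)cc12` 0%

Compound 1 gives the largest number of the three; compound 2 lies within the scatter of it, compound 3 lies beyond the scatter below it. Compound 4 `COc1ccc(-c2ccccc2)c2cc(C(=O)Nc3ccncc3)oc12` is not yet measured. Its change from compound 1 is pyridin-4-yl in place of methyl on an amide-type nitrogen.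

Within the data shown here, no measured step touches the amide nitrogen. Among the measured compounds shown here, the one measured step, a number 12 percentage points lower from compound 2 to compound 3 (beyond the scatter), concerns an aromatic carbon and does not bear on this change. Compound 2, carrying an aryl group on the amide nitrogen, shows a number within the scatter of compound 1, so a large ring on that nitrogen has not yet moved this read-out. The expected step of a number 5 percentage points lower from compound 1 to compound 4 (within the scatter) therefore stays within the scatter. Compound 4 is estimated at 13%, range 0% to 28%.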

Compound 4, a percentage reported as inhibition, in the whole organism at one dose (the size of the read-out at that dose, not a potency): 40%
Estimate against measurement, compound 4: 27 percentage points below, and the stated range ends below it.
By their numbers in this assay, from the lowest: compound 3; then compounds 2 and 1 (each within the scatter of the next); then compound 4.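

In this assay, the amide nitrogen proves able to move the read-out: pyridin-4-yl in place of methyl gives a number 22 percentage points higher from compound 1 to compound 4 (beyond the scatter). A ring on that nitrogen does not guarantee such a number: compound 2, with an aryl group there, gives 12%, and compound 4 gives 40%. No evidence bears on the origin of this step.

Open, from the compounds shown here alone, is whether the outcome depends on the ring nitrogen and where it sits, which pyridin-3-yl on the amide nitrogen would test. Also open, going by these compounds, is how a non-aromatic 2-(dimethylamino)ethyl chain there would compare.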